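A few compounds are considered here, and "the series" means these few. Any claim that something is new, unique, unknown or untested is made for them only; others in the source may bear on it.

Compound 1 `c1ccc(-c2ccc(-c3ccc(-c4nc5ccccc5[nH]4)cc3)cc2)cc1`: 41200 nM
Compound 2 `Clc1cccc(-c2ccc(-c3ccc(-c4nc5ccccc5[nH]4)cc3)cc2)c1`: 31100 nM

In a functional assay on A549 cells (Homo sapiens) for inhibition, read by sulforhodamine B assay (a lower number here means a stronger inhibitor of growth, a higher number a weaker inhibitor of growth), compound 1 gives 41200 nM. Among the measured compounds shown here, only one other measured compound can place it, and the step is a 1.3-fold lower number from compound 1 to compound 2 (0.12 log units; within the scatter), so compound 1 holds no distinct position on these numbers. Compound 3 `Oc1cccc2[nH]c(-c3ccc(-c4ccc(-c5ccccc5)cc4)cc3)nc12` keeps the core of compound 1 but has hydroxy in place of hydrogen on an aromatic carbon. The chloro in place of hydrogen in the step above is the only measured substitution, and it is a different group at a different place. It offers weak guidance, but gives no reason to expect a step beyond the scatter. The expected change is a 1.4-fold lower number from compound 1 to compound 3 (0.14 log units; within the scatter). For compound 3 the estimated value is 30000 nM, with an expected range of 10000 nM to 70000 nM.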

Compound 3, concentration for 50% growth inhibition: 8320 nM
Estimate against measurement, compound 3: 3.6-fold (0.56 log units) above; measured number outside the range, below it.
By their numbers in this assay, from the lowest: compound 3; then compounds 2 and 1 (each within the scatter of the next).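

In this assay, hydroxy in place of hydrogen on an aromatic carbon of the shared core, ortho to a fused ring and meta to a fused ring, gives a 5.0-fold lower number from compound 1 to compound 3 (0.69 log units; beyond the scatter), a modest step but the first single change shown that lies beyond the scatter. The chloro change elsewhere in the molecule, a 1.3-fold lower number from compound 1 to compound 2 (0.12 log units; within the scatter), did not, so the core of compound 1 is shown to respond to a substitution at this position. No measured information available here accounts for this step.

The compounds shown leave open whether this step is specific to hydroxy, since a methoxy, an amine or a fluorine at the same carbon would be needed to tell. They also leave open whether hydroxy on the other carbons of that ring would give a similar step.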